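The compounds below may be only part of what the source reports. "The series", "measured", "known", "first", "only" and "open" are said of these compounds alone.

Compound 1 `O=C(O)CC/C=C\CC1COC(c2ccccc2Cl)OC1c1cccnc1` gives 759 nM in a functional assay for inhibition, with Homo sapiens as the target; a lower number here means tighter binding, a higher number weaker binding.
Compound 2 `N#Cc1ccc(C2OCC(C/C=C\CCC(=O)O)C(c3cccnc3)O2)cc1` gives 1290 nM in this assay.
Compound 3 `Cc1ccc(C#N)c(OC(C)(C)C2OCC(C/C=C\CCC(=O)O)C(c3cccnc3)O2)c1` gives 15.9 nM in this assay.

Compound 3 has the lowest number of the three, and its distance from both compound 1 and compound 2 lies well beyond the usual scatter, so it binds most tightly among the measured compounds. Compound 4 `CC(C)(Cc1ccc(F)cc1C#N)C1OCC(C/C=C\CCC(=O)O)C(c2cccnc2)O1` has not yet been measured. It differs from compound 3 by a group of 10 heavy atoms (8 carbon, 1 nitrogen, 1 fluorine; one six-membered aromatic ring of carbon only) in place of a group of 10 heavy atoms (8 carbon, 1 nitrogen, 1 oxygen; one six-membered aromatic ring of carbon only), on a saturated chain carbon bound to two saturated chain carbons and a saturated ring carbon. Within the data shown here, the only measured step, a 1.7-fold higher number from compound 1 to compound 2 (0.23 log units; within the scatter), concerns a different place, the aryl group on a saturated ring carbon, and it stayed within the scatter; no measured step touches the chain carbon that changes here. What the data do show is that the large drop from compound 1 to compound 3 goes with the substituted group on that chain carbon, and compound 4 keeps a group of the same size there, again with one aromatic ring and a nitrile. On that basis the expectation is a step of only modest size, a 1.6-fold higher number from compound 3 to compound 4 (0.20 log units; within the scatter), with wide uncertainty in either direction. Compound 4 is therefore estimated at 25 nM, with a likely range from 6 nM to 100 nM.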

Compound 4, dissociation constant: 2.19 nM
The estimate for compound 4 lay 11-fold (1.06 log units) above the measured number; measured number below the stated range.
By their numbers in this assay, from the lowest: compound 4; then compound 3; then compounds 1 and 2 (each within the scatter of the next).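

At the saturated chain carbon bound to two saturated chain carbons and a saturated ring carbon, the result in this assay shows that group size alone does not settle the outcome: the exchange gives a 7.3-fold lower number from compound 3 to compound 4 (0.86 log units; beyond the scatter), which lies beyond the usual scatter, although both groups have 10 heavy atoms, one six-membered aromatic ring of carbon only and 1 triple bond outside aromatic rings. Among these compounds, this is the first measured step at this position, and it shows that groups matched on those counts can still be told apart, with the oxygen leaving, a fluorine entering, and the hydrogen-bond acceptors of the group going from 2 to 1. Nothing measured here bears on why the number falls.

From the compounds shown here alone, a single step cannot separate the loss of the oxygen from the gain of the fluorine, so it remains open which of the two goes with the lower number. The compounds shown also leave open how a group with chlorine in place of the fluorine, or one carrying an amine, would behave at this position.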